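A few compounds are considered here, and "the series" means these few. Any claim that something is new, unique, unknown or untested is made for them only; others in the source may bear on it.

Measured in an in vitro ADME assay on microsomes (Homo sapiens) for metabolic stability; a higher number here means that the compound lasts longer, a lower number that the compound disappears faster:

- compound 1 `Cc1c2c(n3c1CCN(C(=O)[C@H](C)N)CC[C@H](C)Nc1cc-3ccc1C(N)=O)CC(C)(C)CC2=O` gives 0.433 h
- compound 2 `CC[C@H](N)C(=O)N1CCc2c(C)c3c(n2-c2ccc(C(N)=O)c(c2)N[C@@H](C)[C@H](C)C1)CC(C)(C)CC3=O` gives 0.417 h
- compound 3 `Cc1c2c(n3c1CCN(C(=O)[C@@H](N)C(C)C)C[C@@H](C)[C@H](C)Nc1cc-3ccc1C(N)=O)CC(C)(C)CC2=O` gives 0.133 h

Compound 3 has the lowest number of the three, and the gaps up to compound 1 and compound 2 both lie beyond the scatter. The next structure is compound 4 `Cc1c2c(n3c1CCN(C(=O)C1(N)CCCC1)C[C@@H](C)[C@H](C)Nc1cc-3ccc1C(N)=O)CC(C)(C)CC2=O`, which differs from compound 3 in one group: 1-aminocyclopentyl in place of 1-amino-2-methylpropyl on a carbonyl carbon. In words, 1-aminocyclopentyl stands in place of 1-amino-2-methylpropyl on a carbonyl carbon.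

Within the data shown here, only one measured step falls in this group. That is a 3.1-fold lower number from compound 2 to compound 3 (0.50 log units; beyond the scatter), a modest change that came with a methyl in place of hydrogen on a saturated chain carbon. Among the measured compounds shown here, no measured compound carries a ring in this group, so the data give no firm direction for the new change. A step of similar or smaller size is expected in this assay, quite possibly within the scatter. The estimated change is a 1.2-fold higher number from compound 3 to compound 4 (0.08 log units; within the scatter). Compound 4 is expected at 0.16 h, with an estimated range from 0.07 h to 0.35 h.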

Compound 4, half-life: 0.0667 h
Compound 4: the middle estimate sits 2.4-fold (0.38 log units) above what was measured; the measured number lies below the stated range.
By their numbers in this assay, from the lowest: compounds 4 and 3 (each within the scatter of the next); then compounds 2 and 1 (each within the scatter of the next).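

On the carbonyl carbon in this assay, the ring of 1-aminocyclopentyl gives a 2.0-fold lower number from compound 3 to compound 4 (0.30 log units; within the scatter) in place of the open 1-amino-2-methylpropyl, so these two groups cannot be told apart here. Set against 1-aminopropyl, the same ring gives a 6.3-fold lower number from compound 2 to compound 4 (0.80 log units; beyond the scatter) and this step is the larger of the two listed for the new compound, so both 1-aminocyclopentyl and 1-amino-2-methylpropyl now stand beyond the scatter from 1-aminopropyl in this assay. Nothing available accounts for these numbers.

The compounds shown leave open whether a smaller or larger ring on this carbon, such as 1-aminocyclopropyl or 1-aminocyclohexyl, would fall with these two groups or with 1-aminopropyl. They also leave open how a group with a hydroxyl in place of the amine would behave here.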